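Saturating the vinyl of compound 2: expected effect on binding

A few compounds are considered here, and "the series" means these few. Any claim that something is new, unique, unknown or untested is made for them only; others in the source may bear on it.

Working notes on the series. Compound 1 `C=CC(=O)O[C@@H](Cc1ccccc1)CN1CCN(CCCN(c2ccc(F)cc2)c2ccc(F)cc2)CC1` gives 3.26 nM in an assay on membranes from striatum for displacement of a labelled ligand from sodium-dependent dopamine transporter (Rattus norvegicus); a lower number here means a stronger inhibitor, a higher number a weaker inhibitor. Compound 3 `O[C@@H](Cc1ccccc1)CN1CCN(CCCN(c2ccc(F)cc2)c2ccc(F)cc2)CC1` carries hydrogen in place of vinylcarbonyl on an oxygen on a saturated carbon and gives 1.72 nM; the step of a 1.9-fold lower number from compound 1 to compound 3 (0.28 log units; within the scatter) stays within the scatter, so the two values are read as equivalent. Compound 2 `C=CC(=O)OC(CCN1CCN(CCCN(c2ccc(F)cc2)c2ccc(F)cc2)CC1)c1ccccc1` gives 6.71 nM and stands highest of the three numbers, separated from both compound 1 and compound 3 by more than the scatter.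

Compound 4 `CCC(=O)OC(CCN1CCN(CCCN(c2ccc(F)cc2)c2ccc(F)cc2)CC1)c1ccccc1` differs from compound 2 in one place: ethyl in place of vinyl on a carbonyl carbon. For the measured compounds named here, no measured step exchanges vinyl for ethyl on a carbonyl carbon, so there is no direct precedent in this set. Going by the values given here, the only step that touches the same region is a 1.9-fold lower number from compound 1 to compound 3 (0.28 log units; within the scatter), where removing the entire vinylcarbonyl moved the number by less than the scatter. A change that keeps the propanoyloxy group in place and alters only the end of the acyl chain is therefore expected to move the number even less, with no direction preferred.

Compound 4 is expected to give 6.5 nM, with a range of 2.5 nM to 16 nM. The expected step of a 1.0-fold lower number from compound 2 to compound 4 (0.01 log units; within the scatter) is estimated to fall within the scatter.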

Compound 4, inhibition constant: 5.57 nM
Beside the measured number, compound 4's estimate is 1.2-fold (0.07 log units) above it; the range from low to high includes it.
By their numbers in this assay, from the lowest: compounds 3, 1, 4 and 2 (each within the scatter of the next, the first and the last beyond it).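

In this assay, for the compounds shown here, ethyl in place of vinyl on a carbonyl carbon gives a 1.2-fold lower number from compound 2 to compound 4 (0.08 log units; within the scatter), the only direct reading of this exchange, so vinylcarbonyl and propanoyl read as equivalent at this position. In this one pair, the double bond outside aromatic rings is therefore not needed to keep the number in the range of compound 2. The earlier step of a 1.9-fold lower number from compound 1 to compound 3 (0.28 log units; within the scatter) concerned the loss of the whole vinylcarbonyl on a different core and could not separate the end of the acyl chain from the rest of the group, and no supporting measurement is available on why the two acyl groups read alike.

The compounds shown leave open how far this acyl end can change before the number moves beyond the scatter, for instance with a longer chain, a phenyl group or a terminal amine. They also leave open whether hydrogen in place of propanoyl on the oxygen, which would give the free alcohol on the core of compound 4, would read the same way as the step on the core of compound 1.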